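The source may hold more compounds than are shown below. What is called first, only, known or untested is meant among the compounds shown, and "the series" means these compounds.

Working notes on the series, read in an ADME assay on L6 cells (Rattus norvegicus) for cytotoxicity; a lower number here means a stronger inhibitor, a higher number a weaker inhibitor. Compound 1 (`CCc1ccc(C(=O)NCCCN2CCN(CCCNc3ccnc4cc(Cl)ccc34)CC2)cc1`) gives 3900 nM and compound 2 (`O=C(NCCCN1CCN(CCCNc2ccnc3cc(Cl)ccc23)CC1)c1ccc(F)c(F)c1`) gives 10000 nM, so compound 2 holds the higher of the two numbers and is the weaker inhibitor of the pair. Next comes compound 3 (`O=C(NCCCN1CCN(CCCNc2ccnc3cc(Cl)ccc23)CC1)c1cc(F)cc(F)c1`), with the change 3,5-difluorophenyl in place of 3,4-difluorophenyl on a carbonyl carbon. Among the compounds with values here, only one measured step bears on this: a 2.6-fold higher number from compound 1 to compound 2 (0.41 log units; beyond the scatter), a modest step with 3,4-difluorophenyl in place of 4-ethylphenyl on that carbonyl carbon. Compound 3 has the same atoms as compound 2 at 10000 nM, joined differently, so a smaller step than that one is expected, probably none beyond the scatter, with no firm direction. The expected move is a 1.1-fold lower number from compound 2 to compound 3 (0.05 log units; within the scatter). For compound 3 the estimated value is 9000 nM, with an expected range of 4500 nM to 18000 nM.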

Compound 3, half-maximal inhibitory concentration: 11600 nM
For compound 3 the middle estimate is 1.3-fold (0.11 log units) below the measured one; the measured number falls inside the stated range.
By their numbers in this assay, from the lowest: compound 1; then compounds 2 and 3 (each within the scatter of the next).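

In this assay the shift from 3,4-difluorophenyl to 3,5-difluorophenyl on the carbonyl carbon gives a 1.2-fold higher number from compound 2 to compound 3 (0.06 log units; within the scatter) and so registers no change beyond the scatter for this rearrangement of the two fluorines. The gap to the 4-ethylphenyl amide persists with the second difluorophenyl group, which shows a 3.0-fold higher number from compound 1 to compound 3 (0.47 log units; beyond the scatter) alongside the earlier 2.6-fold higher number from compound 1 to compound 2 (0.41 log units; beyond the scatter) in the same direction. No measurement on hand speaks to the origin of either step.

Still open, going by these compounds, is whether the ethyl group lowers the number or the fluorines raise it, a question that unsubstituted phenyl or 4-fluorophenyl on the same carbonyl carbon would address. Also open, on these data alone, is whether a longer chain than ethyl, such as 4-propylphenyl, or a methoxy group in its place would extend the gap.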